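A few compounds are considered here, and "the series" means these few. Any claim that something is new, unique, unknown or untested is made for them only; others in the source may bear on it.

Measured so far:
compound 1, `CC(C)C(NC(=O)NO)C(=O)NC1CCCC1`: > 200000 nM
compound 2, `CCC(C)C(NC(=O)n1nnc2ccccc21)C(=O)NC1CCCCC1`: 107000 nM

In a functional assay on CCRF-CEM cells (Homo sapiens) for inhibition (on this read-out lower numbers stand for stronger inhibition and higher numbers for weaker inhibition), compound 2 holds the only plain number shown in the series. Compound 1 sits at the limit of > 200000 nM in this assay, at which 1 of the 2 values shown sits, a limit of the assay and not a number. Within the data shown here, no pair of measured compounds differs in one place, so no measured step exists to weigh a change against.

Compound 3 `CCC(C)C(NC(=O)n1nnc2ccccc21)C(=O)NCc1ccccc1` differs from compound 2 by benzyl in place of cyclohexyl on an amide-type nitrogen. No measured pair shows this change, and the only number shown gives no lean in either direction, so the step from compound 2 to compound 3 is expected to fall within the usual scatter, a 1.1-fold lower number from compound 2 to compound 3 (0.03 log units; within the scatter). Compound 3 is therefore expected to give about 100000 nM in this assay, between 40000 nM and 250000 nM, with a real chance that the assay reports only a limit.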

Compound 3, half-maximal inhibitory concentration: 164000 nM
Compound 3: middle estimate off by 1.6-fold (0.21 log units), on the low side; low and high end bracket the measured number.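

In this assay, the amide-type nitrogen now has its first readable step: benzyl in place of cyclohexyl gives a 1.5-fold higher number from compound 2 to compound 3 (0.19 log units; within the scatter). An aromatic ring and a non-aromatic ring of carbon only therefore cannot be told apart at this position, and neither compound 2 nor compound 3 separates from the other on this read-out. Compound 1 remains a limit and not a number, so it adds no step to this comparison: the limit of > 200000 nM in this assay, at which 1 of the 3 values shown sits.

Going by these compounds, whether any other group on this nitrogen departs from cyclohexyl and benzyl stays open, for example a chain ending in an amine or a benzyl group carrying a carboxylic acid. On these data alone, what a change elsewhere in the core of compound 2 would do in this assay stays open as well.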